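Ethyl for phenyl on the ring nitrogen: compound 4

A few compounds are considered here, and "the series" means these few. Any claim that something is new, unique, unknown or untested is made for them only; others in the source may bear on it.

Working notes on the series. Compound 1 `CCn1nc(Cc2ccc(SC)cc2)c2ccccc2c1=O` has been measured in a functional assay on aorta with Alpha-1D adrenergic receptor (Rattus norvegicus) as the target (on this read-out higher numbers stand for an effect only at larger amounts of compound and lower numbers for an effect already at smaller amounts), and returns only a limit, > 100000 nM. Compound 2 `COc1ccc(Cc2nn(-c3ccccc3)c(=O)c3ccccc23)cc1OC` likewise returns only a limit in this assay, > 100000 nM. Compound 3 `O=c1c2ccccc2c(Cc2ccc(Cl)cc2)nn1-c1ccc(Br)cc1` also stands at a limit, > 30000 nM. Compound 2 therefore sits at the limit of > 100000 nM in this assay, at which 2 of the 3 values shown sit, while the third value sits at the limit of > 30000 nM in this assay, at which 1 of the 3 values shown sits. Within the data shown here, none of the three is a number, so no step between measured compounds can be sized, and nothing orders compound 2 against compound 1 or compound 3.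

Compound 4 `CCn1nc(Cc2ccc(OC)c(OC)c2)c2ccccc2c1=O` is the next to be measured. It differs from compound 2 in one place: ethyl in place of phenyl on an aromatic nitrogen. Compound 1 also carries ethyl on an aromatic nitrogen and sits at > 100000 nM.

The step of a number no higher from compound 2 to compound 4 (the limit leaves the size open) is expected to be none beyond the usual scatter. Compound 4 is expected to give 100000 nM in this assay, with a range from 30000 nM to 300000 nM, and most probably again as a limit rather than a number.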

Compound 4, half-maximal effective concentration: 5300 nM
Estimate against measurement, compound 4: 19-fold (1.28 log units) above; the whole stated range lies above it.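

Among these compounds, the aromatic nitrogen is the first position where a change gives a number in this assay rather than a limit: ethyl in place of phenyl at this position gives an at least 18-fold lower number from compound 2 to compound 4 (1.27 log units; beyond the scatter). This size is a minimum, because compound 2 stands at a limit and not at a number: the limit of > 100000 nM in this assay, at which 2 of the 4 values shown sit.
Ethyl on the aromatic nitrogen is not enough by itself, and compound 1 goes against any such rule: compound 1, which also carries ethyl there, stands at a limit in this assay, > 100000 nM.

From the compounds shown here alone, whether the lower number belongs to ethyl alone stays open, since a single step cannot show whether methyl, a longer chain such as butyl, or a chain ending in an amine on the same nitrogen would give a similar, lower or higher number. The part played by the two methoxy groups of compound 4 also stays open, since no compound shown pairs them with ethyl in a way that differs from compound 4 in one place only.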